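The source may report more compounds than this note shows. Statements on the series, on what has been measured and on what is new or still open speak of the compounds shown alone.

Measured so far in an assay on isolated protein for inhibition of Amine oxidase [flavin-containing] A (Homo sapiens), read by fluorescence, with a stated time of 20 min; on this read-out higher numbers stand for weaker inhibition and lower numbers for stronger inhibition:
Compound 1, `CC(C)=NNc1nc(-c2cccc([N+](=O)[O-])c2)cs1`, gives 1070 nM.
Compound 2, `CC/C(C)=N\Nc1nc(-c2cccc([N+](=O)[O-])c2)cs1`, gives 20500 nM.

Among the measured compounds shown here, compound 2 stands at the higher of the two numbers, and the only step known is the one that leads to it: a 19-fold higher number from compound 1 to compound 2 (1.28 log units; beyond the scatter). That step was large, and it weakened the inhibition well beyond the usual scatter.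

Compound 3, `CCC/C(C)=N\Nc1nc(-c2cccc([N+](=O)[O-])c2)cs1`, has not yet been measured. It differs from compound 2 by methyl in place of hydrogen on a saturated chain carbon, two bonds along the chain from a carbon with a double bond to nitrogen, so the same kind of addition seen between compound 1 and compound 2 is repeated, cut one bond further out: ethyl to propyl. For the measured compounds named here, only the step from compound 1 to compound 2 bears on this change. Going by the values given here, nothing among the measured compounds shows whether a second addition of the same kind acts as strongly, more weakly, or not at all, so the expectation is a further rise in the number, smaller than the first and with a wide range. The change is therefore estimated to give a 2.2-fold higher number from compound 2 to compound 3 (0.34 log units; beyond the scatter). For compound 3 the expected value is 45000 nM, with a range from 12000 nM to 170000 nM.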

Compound 3, half-maximal inhibitory concentration: 38000 nM
Compound 3: the middle estimate sits 1.2-fold (0.07 log units) above what was measured; the measured number falls inside the stated range.
By their numbers in this assay, from the lowest: compound 1; then compounds 2 and 3 (each within the scatter of the next).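

In this assay, lengthening the chain from ethyl to propyl gives a 1.9-fold higher number from compound 2 to compound 3 (0.27 log units; within the scatter), so this second added methyl has no effect that can be told apart from the scatter, whereas the first addition, a 19-fold higher number from compound 1 to compound 2 (1.28 log units; beyond the scatter), lay well beyond it. Placing ethyl instead of hydrogen on the saturated chain carbon bound to the carbon with a double bond to nitrogen gives a 36-fold higher number from compound 1 to compound 3 (1.55 log units; beyond the scatter), which is also beyond the scatter, so the large weakening relative to compound 1 remains and is already almost complete with the first added methyl. No measurement available here explains why the first addition matters so much and the second so little at this position.

As far as these compounds go, with only these three compounds, it remains open whether a longer chain such as butyl would leave the number where it is or move it again. From the compounds shown here alone, it is equally open how a branched isopropyl group, a cyclohexane ring, or a chain ending in an amine or a carboxylic acid would behave at this position.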